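The source may report more compounds than this note shows. Statements on the series, on what has been measured and on what is new or still open speak of the compounds shown alone.

Working notes on the series, read in a functional assay on HeLa cells (Homo sapiens) for antiproliferative activity, with a stated time of 48 h; on this read-out lower numbers stand for stronger inhibition and higher numbers for weaker inhibition. Compound 1 `Cc1cc(=O)c2c(O)cc(OC[C@@H]3CO3)cc2o1` gives 11900 nM, and compound 2 `Cc1cc(=O)c2c(OC[C@@H]3CO3)cc(OC[C@@H]3CO3)cc2o1` gives 21700 nM. For the measured compounds named here, these are the only two numbers so far and they lie within the scatter of each other, so compound 2 holds no distinct rank.

Compound 3 `Cc1cc(=O)c2c(OC[C@H]3CO3)cc(OC[C@@H]3CO3)cc2o1` is unmeasured and differs from compound 2 in configuration only: the two compounds have the same atoms and bonds and differ only in configuration as drawn: 1 of 2 stereo elements differ; a stereocentre at a saturated ring carbon is drawn S in compound 2 and R in compound 3. A stereocentre at a saturated ring carbon is drawn S in compound 2 and R in compound 3.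

Going by the values given here, the only measured step is a 1.8-fold higher number from compound 1 to compound 2 (0.26 log units; within the scatter). It places (oxiran-2-yl)methyl in place of hydrogen on an oxygen on an aromatic ring, so it bears on the new change only indirectly. Among the compounds with values here, no measured pair differs in configuration alone, which leaves the direction open. Since that step stayed within the scatter, no step beyond the scatter is expected in this assay for this change, though a real stereochemical effect cannot be excluded.

The expected step is a 1.1-fold lower number from compound 2 to compound 3 (0.04 log units; within the scatter). Compound 3 is estimated at 20000 nM, with an expected range of 9000 nM to 42000 nM.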

Compound 3, half-maximal inhibitory concentration: 1770 nM
Beside the measured number, compound 3's estimate is 11-fold (1.05 log units) above it; the measured number lies below the stated range.
By their numbers in this assay, from the lowest: compound 3; then compounds 1 and 2 (each within the scatter of the next).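

At the oxygen that carries hydrogen in compound 1, (oxiran-2-yl)methyl does not act the same way in both of its drawn forms in this assay: with its saturated ring carbon drawn R it gives a 6.7-fold lower number from compound 1 to compound 3 (0.83 log units; beyond the scatter), whereas drawn S it gives a 1.8-fold higher number from compound 1 to compound 2 (0.26 log units; within the scatter). Inverting this one stereocentre from S to R gives a 12-fold lower number from compound 2 to compound 3 (1.09 log units; beyond the scatter), the first step in the series beyond the scatter that involves this position alone, so the drawn configuration here decides whether the added group makes a measurable difference. The large step can be assigned to configuration rather than to any gain or loss of atoms because of this: the fact that compounds 2 and 3 differ only in the configuration as drawn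

The compounds shown leave open whether the other stereocentre, drawn the same in compound 2 and compound 3, responds to inversion in the same way. They also do not tell whether the R-configured oxirane ring itself is needed at this oxygen, or whether an open-chain 2,3-dihydroxypropyl group or an amine-bearing chain would serve there.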